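This account rests on a few compounds, and the source may have more. Where it says the series, first, only, none or still open, it means among the compounds named here.

In an ADME assay on Caco-2 cells (Homo sapiens) for permeability, read by LC-MS, in the apical to basolateral direction, with a stated time of 60 min, at pH 6.5 (a higher number here means that the compound crosses the layer faster, a lower number that the compound crosses the layer more slowly), compound 1 `O=C(NCc1cc(Cl)ccc1-n1cnnn1)[C@@H]1CC=NN1C(=O)[C@H](O)c1ccccc1F` gives 8.9 10^-6 cm/s and compound 2 `O=C(NCc1cc(Cl)ccc1-n1cnnn1)[C@@H]1CC=NN1C(=O)[C@H](O)Cc1ccccc1` gives 11 10^-6 cm/s. Going by the values given here, compound 2 therefore stands within the scatter of compound 1, the only other compound measured so far. Compound 3 `COC(C)(C)[C@@H](O)C(=O)N1N=CC[C@H]1C(=O)NCc1cc(Cl)ccc1-n1cnnn1` keeps the shared core of compound 2 and differs in one group: 1-methoxy-1-methylethyl in place of benzyl on a saturated chain carbon bound to a carbonyl carbon and an oxygen on a saturated carbon. In words, 1-methoxy-1-methylethyl takes the place of benzyl on a saturated chain carbon bound to a carbonyl carbon and an oxygen on a saturated carbon. Among the compounds with values here, only one measured step bears on this change, a 1.2-fold higher number from compound 1 to compound 2 (0.09 log units; within the scatter), in which benzyl took the place of 2-fluorophenyl at that same place. That step exchanged one ring-bearing group for another, whereas here the ring leaves and no ring enters, so it is only a loose guide. Within the data shown here, no measured pair shows such a loss, so the range must stay wide. The estimate means a 1.6-fold lower number from compound 2 to compound 3 (0.20 log units; within the scatter), an expected step that stays within the scatter. For compound 3 the expected value is 7 10^-6 cm/s, with an estimated range from 2.5 10^-6 cm/s to 15 10^-6 cm/s.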

Compound 3, apparent permeability: 1.7 10^-6 cm/s
Estimate against measurement, compound 3: 4.1-fold (0.61 log units) above, and the stated range ends above it.
By their numbers in this assay, from the lowest: compound 3; then compounds 1 and 2 (each within the scatter of the next).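

In this assay, the place on a saturated chain carbon bound to a carbonyl carbon and an oxygen on a saturated carbon now proves sensitive to what stands on it: 1-methoxy-1-methylethyl in place of benzyl gives a 6.5-fold lower number from compound 2 to compound 3 (0.81 log units; beyond the scatter) and in place of 2-fluorophenyl gives a 5.2-fold lower number from compound 1 to compound 3 (0.72 log units; beyond the scatter), whereas the exchange between the two ring-bearing groups had left the number within the scatter. Among these compounds, the two with an aromatic ring at this place therefore stand together, and compound 3, with no ring there, stands apart from both. The change to compound 3 alters several things at once, since the ring leaves, the group loses heavy atoms and a hydrogen-bond acceptor enters, and no measurement shown here links the drop to any one of them.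

From the compounds shown here alone, it remains open whether the lower number goes with the loss of the aromatic ring or with the oxygen of the methoxy group. A tert-butyl group at this place would keep the branched chain without that oxygen, and a cyclohexyl group would restore a ring without aromaticity, so the two would begin to separate these readings.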